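The compounds below may be only part of what the source reports. "The series", "measured", "known", "first", "only" and "open" are said of these compounds alone.

Compound 3 `FC(F)(F)c1ccc(-c2ccc3c(NCCCNCc4ccco4)ccnc3c2)cc1` is one of three compounds that share a core and differ only in the group attached to one aromatic carbon of that core. In an ADME assay for permeability, using PAMPA, with a stated time of 30 min, at pH 7.4 (on this read-out lower numbers stand for lower permeability and higher numbers for higher permeability), compound 3 gives 237 10^-6 cm/s. Compound 2 `COc1ccc(-c2ccc3c(NCCCNCc4ccco4)ccnc3c2)cc1` gives 237 10^-6 cm/s in this assay, and these two values sit level, together the highest of the three; the change from methoxy to trifluoromethyl produced no change at the digits printed from compound 2 to compound 3 (within the scatter). Compound 1 `CC(C)Cc1ccc2c(NCCCNCc3ccco3)ccnc2c1`, which carries isobutyl at the same position, gives 23 10^-6 cm/s in this assay, and the replacement of isobutyl by an aryl group gave a 10-fold higher number from compound 1 to compound 2 (1.01 log units; beyond the scatter) and a 10-fold higher number from compound 1 to compound 3 (1.01 log units; beyond the scatter).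

Compound 4 `c1ccc(CCc2ccc3c(NCCCNCc4ccco4)ccnc3c2)cc1` has not yet been measured. It differs from compound 3 in one place: phenethyl in place of 4-(trifluoromethyl)phenyl on an aromatic carbon.

Two of the measured steps bear on this change. The large step of a 10-fold higher number from compound 1 to compound 3 (1.01 log units; beyond the scatter) shows that swapping an alkyl group for an aryl group raised the number strongly, while no change at the digits printed from compound 2 to compound 3 (within the scatter) shows that exchanging one aryl substituent for another left it unchanged. Phenethyl contains an aromatic ring like compounds 2 and 3, but joins the core through a saturated chain like compound 1, so for compound 4 a result between those two levels is expected, with a step of a 1.6-fold lower number from compound 3 to compound 4 (0.20 log units; within the scatter). The value of compound 4 in this assay is estimated at 150 10^-6 cm/s, in a range from 50 10^-6 cm/s to 300 10^-6 cm/s.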

Compound 4, apparent permeability: 23 10^-6 cm/s
Estimate against measurement, compound 4: 6.5-fold (0.81 log units) above; the measured number lies below the stated range.
By their numbers in this assay, from the lowest: compounds 1 and 4 (each within the scatter of the next); then compounds 2 and 3 (each within the scatter of the next).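

Carrying an aromatic ring is not enough to reach the high level at this position: phenethyl has one six-membered aromatic ring of carbon only, as the groups of compound 2 and compound 3 do, yet this assay shows a 10-fold lower number from compound 3 to compound 4 (1.01 log units; beyond the scatter) and a 10-fold lower number from compound 2 to compound 4 (1.01 log units; beyond the scatter). The phenethyl group, whose ring stands at the end of a saturated chain, also gives nothing above the isobutyl group, with no change at the digits printed from compound 1 to compound 4 (within the scatter). Across these four compounds, with none going against it, the two high numbers belong to the groups whose aromatic ring is bonded straight to the shared core, and the two low numbers belong to the groups attached through a saturated carbon; no measurement shown here gives a reason for this split.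

Two compounds on each side cannot show whether the direct ring bond is what matters, and a plain benzyl or phenyl group at this position would test that more closely. From the compounds shown here alone, it also stays open where a cyclohexyl group, with a saturated ring bonded to the core, or a phenoxy group, with an oxygen as the link, would fall.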